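Aryl changes on a shared core and cytotoxicity

This account rests on a few compounds, and the source may have more. Where it says the series, first, only, none or still open, it means among the compounds named here.

Compound 1 `CC(C)=CCC/C(C)=C/CC/C(C)=C/CC[C@@H]1[C@@]2(C)CC/C(=N\OCc3cn(-c4ccccc4)nn3)C(C)(C)[C@@H]2CC[C@@]1(C)O`: 8830 nM
Compound 2 `CC(C)=CCC/C(C)=C/CC/C(C)=C/CC[C@@H]1[C@@]2(C)CC/C(=N\OCc3cn(-c4cccc([N+](=O)[O-])c4)nn3)C(C)(C)[C@@H]2CC[C@@]1(C)O`: 17400 nM
Compound 3 `CC(C)=CCC/C(C)=C/CC/C(C)=C/CC[C@@H]1[C@@]2(C)CC/C(=N\OCc3cn(-c4cccc(C(F)(F)F)c4)nn3)C(C)(C)[C@@H]2CC[C@@]1(C)O`: 11800 nM

In a functional assay on DU-145 cells (Homo sapiens) for cytotoxicity, read by MTT assay, with a stated time of 48 h (a higher number here means a weaker inhibitor, a lower number a stronger inhibitor), compound 1 stands at the lowest of the three numbers, yet its gaps to compound 2 (a 2.0-fold higher number from compound 1 to compound 2 (0.29 log units; within the scatter)) and to compound 3 (a 1.3-fold higher number from compound 1 to compound 3 (0.13 log units; within the scatter)) both lie within the scatter, so the three cannot be told apart. Compound 4 `CC(C)=CCC/C(C)=C/CC/C(C)=C/CC[C@@H]1[C@@]2(C)CC/C(=N\OCc3cn(-c4c(Cl)cc([N+](=O)[O-])cc4Cl)nn3)C(C)(C)[C@@H]2CC[C@@]1(C)O` carries a larger change: 2,6-dichloro-4-nitrophenyl in place of phenyl on an aromatic nitrogen. The two measured steps that bear on it each put a single group, nitro or trifluoromethyl, on the phenyl, and each leaves the number within the scatter of compound 1; compound 4 joins a nitro with two chlorines. A small step is therefore expected, a 1.5-fold higher number from compound 1 to compound 4 (0.17 log units; within the scatter), possibly still inside the scatter. Compound 4 is estimated at 13000 nM, within 5500 nM to 32000 nM.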

Compound 4, half-maximal inhibitory concentration: 16400 nM
Compound 4: the middle estimate sits 1.3-fold (0.10 log units) below what was measured; low and high end bracket the measured number.
By their numbers in this assay, from the lowest: compounds 1, 3, 4 and 2 (each within the scatter of the next).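

Compound 4 shows that the position on the aromatic nitrogen still gives no readable change in this assay when phenyl gives way to the much larger 2,6-dichloro-4-nitrophenyl, with two chlorines added to a nitro: the result is a 1.9-fold higher number from compound 1 to compound 4 (0.27 log units; within the scatter). The other two comparisons agree, with a 1.4-fold higher number from compound 3 to compound 4 (0.14 log units; within the scatter) and a 1.1-fold lower number from compound 2 to compound 4 (0.03 log units; within the scatter), so all four aryl groups remain indistinguishable. Nothing measured here bears on what lies behind these numbers. On these data alone, whether an amine or a carboxylic acid on the phenyl would carry the number beyond the scatter stays open.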